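Swapping 4-acetylphenyl for 1,3-benzothiazol-2-yl on the amide nitrogen

The source may hold more compounds than are shown below. What is called first, only, known or untested is meant among the compounds shown, and "the series" means these compounds.

Compound 1 `COc1ccc2sc(NC(=O)CCCCCCNC(=O)C(O)(O)C(F)(F)F)nc2c1` gives 2180 nM
Compound 2 `COc1ccccc1NC(=O)CCCCCCNC(=O)C(O)(O)C(F)(F)F` gives 10100 nM
Compound 3 `CC(=O)c1ccc(NC(=O)CCCCCCNC(=O)C(O)(O)C(F)(F)F)cc1` gives 12100 nM

These three compounds were tested in a functional assay on HCT-116 cells (Homo sapiens) for inhibition, read by colorimetric assay, with a stated time of 3 days (a higher number here means a weaker inhibitor, a lower number a stronger inhibitor), and carry different groups on the amide-type nitrogen. Compound 3 gives 12100 nM and sits within the scatter of compound 2 at 10100 nM but well above compound 1 at 2180 nM on this scale.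

Compound 4 `O=C(CCCCCCNC(=O)C(O)(O)C(F)(F)F)Nc1nc2ccccc2s1` has not yet been measured. Reaching it from compound 3 puts 1,3-benzothiazol-2-yl in place of 4-acetylphenyl on an amide-type nitrogen.

Going by the values given here, the one measured step, a 1.2-fold higher number from compound 2 to compound 3 (0.08 log units; within the scatter), exchanges one substituted phenyl group for another and so offers little guidance for this larger swap. Compound 1 is the closer guide, as it also carries a five-membered aromatic ring on that nitrogen and gives 2180 nM in this assay as its value. Among the compounds with values here, it is only a single example, so the expectation remains loose. A step beyond the scatter towards a lower number, meaning a stronger inhibitor, is therefore expected. The expected change is a 4.0-fold lower number from compound 3 to compound 4 (0.61 log units; beyond the scatter) in this assay on this reasoning. The estimate for compound 4 is 3000 nM with an expected range from 1100 nM to 8000 nM in this assay when it is measured.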

Compound 4, half-maximal inhibitory concentration: 2370 nM
For compound 4 the middle estimate is 1.3-fold (0.10 log units) above the measured one, and the stated range covers the measured number.
By their numbers in this assay, from the lowest: compounds 1 and 4 (each within the scatter of the next); then compounds 2 and 3 (each within the scatter of the next).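

In this assay, 1,3-benzothiazol-2-yl on the amide-type nitrogen gives a 5.1-fold lower number from compound 3 to compound 4 (0.71 log units; beyond the scatter) when it replaces 4-acetylphenyl and a 4.3-fold lower number from compound 2 to compound 4 (0.63 log units; beyond the scatter) when it replaces 2-methoxyphenyl, whereas exchanging one of those phenyl groups for the other gave only a 1.2-fold higher number from compound 2 to compound 3 (0.08 log units; within the scatter). Among these four compounds, the two with 1,3-benzothiazol-2-yl therefore both have lower numbers than the two with a substituted phenyl group, and the methoxy group of compound 1 is not needed for this: hydrogen in its place gives a 1.1-fold higher number from compound 1 to compound 4 (0.04 log units; within the scatter). Nothing measured here explains why this group on this nitrogen gives a stronger inhibitor in these cells.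

The compounds shown leave open whether both rings of 1,3-benzothiazol-2-yl are needed, since a single five-membered aromatic ring with 2 hetero atoms on the same nitrogen would separate its contribution from that of the six-membered ring. They also leave open how an amine or a carboxylic acid in place of the methoxy group, or a longer chain in the shared linker, would change the number.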